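The source may report more compounds than this note shows. Statements on the series, on what has been measured and on what is new or still open speak of the compounds shown alone.

Compound 3 `NC(=O)c1c(NC(=O)c2ccccc2Cl)sc2c1CCN(C(=S)Nc1ccccc1I)C2` stands lowest of the three numbers in a functional assay on MKN-74 cells (Homo sapiens) for antiproliferative activity, with a stated time of 24 h; on this read-out lower numbers stand for stronger inhibition and higher numbers for weaker inhibition: compound 3 gives 2630 nM, while compound 2 `NC(=O)c1c(NC(=O)c2ccccc2Cl)sc2c1CCN(Cc1ccc(Cl)cc1Cl)C2` gives 16300 nM and compound 1 `NC(=O)c1c(NC(=O)c2ccccc2Cl)sc2c1CCN(Cc1ccc([N+](=O)[O-])cc1)C2` gives 31500 nM. The steps of a 12-fold lower number from compound 1 to compound 3 (1.08 log units; beyond the scatter) and a 6.2-fold lower number from compound 2 to compound 3 (0.79 log units; beyond the scatter) set compound 3 clearly apart from both. Compound 4 `COc1ccc(NC(=S)N2CCc3c(sc(NC(=O)c4ccccc4Cl)c3C(N)=O)C2)cc1` differs from compound 3 by 4-methoxyphenyl in place of 2-iodophenyl on an amide-type nitrogen. Among the measured compounds shown here, no measured step alters the aryl group on the thiourea; the nearest analogy is a 1.9-fold lower number from compound 1 to compound 2 (0.29 log units; within the scatter), a swap of substituents on a phenyl ring that stayed within the scatter. On that basis only a small step is expected, a 1.5-fold higher number from compound 3 to compound 4 (0.18 log units; within the scatter), if anything towards a slightly higher number. Compound 4 is therefore estimated at 4000 nM, with a range from 1500 nM to 12000 nM.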

Compound 4, half-maximal inhibitory concentration: 19600 nM
The estimate for compound 4 lay 4.9-fold (0.69 log units) below the measured number, outside the stated range (above it).
By their numbers in this assay, from the lowest: compound 3; then compounds 2, 4 and 1 (each within the scatter of the next).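

In this assay, the aryl group on the thiourea matters: a 7.5-fold higher number from compound 3 to compound 4 (0.87 log units; beyond the scatter), beyond the scatter, so 4-methoxyphenyl does not keep what 2-iodophenyl gave. With a 1.2-fold higher number from compound 2 to compound 4 (0.08 log units; within the scatter) and a 1.6-fold lower number from compound 1 to compound 4 (0.21 log units; within the scatter), both within the scatter, the thiourea link alone does not set compound 3 apart from the other compounds. No evidence at hand explains this change. Going by these compounds, whether the iodine or its place on the ring drives the step stays open, since both change at once. On these data alone, how a plain phenyl or an alkyl chain on this nitrogen would read also stays open.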